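Methanesulfonamido added to the fluoro compound

This account rests on a few compounds, and the source may have more. Where it says the series, first, only, none or still open, it means among the compounds named here.

In an ADME assay on Huh-7 cells (Homo sapiens) for cytotoxicity (a higher number here means that more compound is tolerated, a lower number that less compound is tolerated), compound 1 `CC(C)CCc1cc(C2=NS(=O)(=O)c3ccccc3N2)c(O)c2ccccc12` gives 37000 nM. Compound 2 `CC(C)CCc1cc(C2=NS(=O)(=O)c3cc(NS(C)(=O)=O)ccc3N2)c(O)c2ccccc12` gives > 100000 nM, which is a limit of the assay and not a number. Compound 3 `CC(C)CCc1c(F)c(C2=NS(=O)(=O)c3ccccc3N2)c(O)c2ccccc12` gives 12000 nM, the lower of the two actual numbers in the series. The fluoro replacement accounts for that position, with a 3.1-fold lower number from compound 1 to compound 3 (0.49 log units; beyond the scatter), a step beyond the scatter.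

Compound 4 `CC(C)CCc1c(F)c(C2=NS(=O)(=O)c3cc(NS(C)(=O)=O)ccc3N2)c(O)c2ccccc12` differs from compound 3 in one place: methanesulfonamido in place of hydrogen on an aromatic carbon. Methanesulfonamido takes the place of hydrogen on an aromatic carbon of the six-membered aromatic ring of carbon only.

For the measured compounds named here, one measured step bears directly on this change, since the same replacement was made on the compound without the fluoro. From the compounds shown here alone, it gave an at least 2.7-fold higher number from compound 1 to compound 2 (0.43 log units; beyond the scatter), a step beyond the scatter whose full size stays open, as its end point is the limit of > 100000 nM in this assay, at which 1 of the 3 values shown sits. Going by the values given here, the fluoro step is of similar size in the opposite direction, but the two replacements have not yet been seen together. If the methanesulfonamido step carries over from compound 2 to the fluoro series, a rise in the number is expected, and the expected size is a 3.5-fold higher number from compound 3 to compound 4 (0.54 log units; beyond the scatter). For compound 4 the estimated value in this assay is 42000 nM, with an expected range from 20000 nM to 100000 nM.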

Compound 4, half-maximal cytotoxic concentration: > 100000 nM
Compound 4: a limit, no number; the forecaster's own chance of this, stated with the estimate: 25%; middle value at least 2.3-fold (0.37 log units) from the limit.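

In this assay, methanesulfonamido in place of hydrogen on this aromatic carbon also raises the number on the fluoro compound, giving an at least 8.3-fold higher number from compound 3 to compound 4 (0.92 log units; beyond the scatter), so the direction of the change now holds on two cores: the same change on two cores in this assay, an at least 2.7-fold higher number (0.43 log units; beyond the scatter) from compound 1 to compound 2 and an at least 8.3-fold higher number (0.92 log units; beyond the scatter) from compound 3 to compound 4; the limit leaves it open whether they differ Compound 4 gives > 100000 nM, which is a limit and not a number, so the fluoro compound, the lowest actual number in the series, moves to the top of the readable range once this group is added. The step from compound 2 to compound 4 cannot be read, so it remains unknown whether the fluoro replacement, which alone gave a 3.1-fold lower number from compound 1 to compound 3 (0.49 log units; beyond the scatter), still lowers the number when methanesulfonamido is present: the limit of > 100000 nM in this assay, at which 2 of the 4 values shown sit.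

From the compounds shown here alone, with both methanesulfonamido compounds at a limit, the true size of the rise, and any difference in it between the two cores, remains open. Also open, going by these compounds, is whether the rise is specific to methanesulfonamido or would appear with an amine, a carboxylic acid or an acetamido group on the same aromatic carbon.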